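Oxime ethers on a naphthyl-substituted core: indanyl in place of benzyl

The source may report more compounds than this note shows. Statements on the series, on what has been measured and on what is new or still open speak of the compounds shown alone.

Measured so far:
- compound 1 `C(=N/OCc1ccccc1)\c1c(-c2ccc3ccccc3c2)nc2occn12` — 840 nM
- compound 2 `Clc1ccc(CO/N=C/c2c(-c3ccc4ccccc4c3)nc3occn23)cc1` — 990 nM

Both numbers come from an assay on HepG2 cells for agonist activity at nuclear receptor subfamily 1 group I member 3 (Homo sapiens), read by a luciferase reporter, with a stated time of 23 h; on this read-out lower numbers stand for an effect already at smaller amounts and higher numbers for an effect only at larger amounts of compound. Compound 2 holds the higher of the two, but a 1.2-fold higher number from compound 1 to compound 2 (0.07 log units; within the scatter), so the two stand level within the scatter.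

Compound 3 `C(=N/OC1Cc2ccccc2C1)\c1c(-c2ccc3ccccc3c2)nc2occn12` is not yet measured. Relative to compound 2 the change is 2,3-dihydro-1H-inden-2-yl in place of 4-chlorobenzyl on an oxygen. Going by the values given here, the single measured step concerns a chloro in place of hydrogen on the aromatic ring, not the ether group itself, so no measured step bears directly on this change. Among the compounds with values here, with only that small step as a guide, the expected change is a 1.0-fold higher number from compound 2 to compound 3 (0.00 log units; within the scatter), with compound 3 estimated at 1000 nM in this assay, range 350 nM to 3000 nM.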

Compound 3, half-maximal effective concentration: 980 nM
Compound 3: the middle estimate sits 1.0-fold (0.01 log units) above what was measured; measured number inside the range.
By their numbers in this assay, from the lowest: compounds 1, 3 and 2 (each within the scatter of the next).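

In this assay, swapping the whole group on the oxygen whose other neighbour is the double-bonded nitrogen gives a 1.0-fold lower number from compound 2 to compound 3 (0.00 log units; within the scatter) when 2,3-dihydro-1H-inden-2-yl replaces 4-chlorobenzyl, and a 1.2-fold higher number from compound 1 to compound 3 (0.07 log units; within the scatter) when it replaces benzyl. Until now this end of the series had been varied only by a chloro on the aromatic ring; compound 3 shows that a different group with an added five-membered non-aromatic ring also stays level with compound 1 and compound 2. Nothing available explains this level result.

From the compounds shown here alone, whether an amine, a carboxylic acid or a longer chain on this oxygen would move the number beyond the scatter remains open. Going by these compounds, the role of the naphthyl group on the shared core also remains open.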